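Swapping the aryl group on a trimethoxyphenyl-benzimidazole core

The source may hold more compounds than are shown below. What is called first, only, known or untested is meant among the compounds shown, and "the series" means these compounds.

Measured compounds:
Compound 1 `COc1cc(-n2cnc3ccc(-c4ccc(C(F)(F)F)cc4)cc32)cc(OC)c1OC` gives 890 nM in a functional assay on SGC-7901 cells (Homo sapiens) for antiproliferative activity, read by MTT assay, with a stated time of 72 h; on this read-out higher numbers stand for weaker inhibition and lower numbers for stronger inhibition.
Compound 2 `COc1cc(-n2cnc3ccc(-c4cccc(C)c4C)cc32)cc(OC)c1OC` gives 3040 nM.
Compound 3 `COc1cc(-n2cnc3ccc(-c4cccc(C)c4)cc32)cc(OC)c1OC` gives 1240 nM.

Compound 1 has the lowest number of the three, though compound 3 sits within the scatter of it, while compound 2 is clearly higher. Compound 4 `COc1cc(-n2cnc3ccc(-c4ccc(C)cc4F)cc32)cc(OC)c1OC` differs from compound 1 by 2-fluoro-4-methylphenyl in place of 4-(trifluoromethyl)phenyl on an aromatic carbon. Among the measured compounds shown here, two steps bear on this: a 1.4-fold higher number from compound 1 to compound 3 (0.14 log units; within the scatter) and a 3.4-fold higher number from compound 1 to compound 2 (0.53 log units; beyond the scatter). Both replacements of the trifluoromethyl-bearing ring raised the number, the larger one when two methyl groups entered. A modest rise is therefore expected for compound 4, as a 1.7-fold higher number from compound 1 to compound 4 (0.23 log units; within the scatter). Compound 4 is estimated at 1500 nM, within a range of 700 nM to 3500 nM.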

Compound 4, half-maximal inhibitory concentration: 5650 nM
Beside the measured number, compound 4's estimate is 3.8-fold (0.58 log units) below it; measured number outside the range, above it.
By their numbers in this assay, from the lowest: compounds 1 and 3 (each within the scatter of the next); then compounds 2 and 4 (each within the scatter of the next).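

At this aromatic carbon, a ring swap can cost far more than compound 3 suggested: in this assay, 2-fluoro-4-methylphenyl gives a 6.3-fold higher number from compound 1 to compound 4 (0.80 log units; beyond the scatter) and a 4.6-fold higher number from compound 3 to compound 4 (0.66 log units; beyond the scatter). Compound 4 instead falls level with the dimethyl compound, with a 1.9-fold higher number from compound 2 to compound 4 (0.27 log units; within the scatter), so those two cannot be told apart. Nothing shown here offers a reason for these shifts.

Whether the fluorine or the methyl drives the loss stays open, since a plain 4-fluorophenyl or 4-methylphenyl ring is not among these compounds. On these data alone, how an amine or a carboxylic acid on this ring would fare is also open.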